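The source may hold more compounds than are shown below. What is called first, only, known or untested is meant among the compounds shown, and "the series" means these compounds.

Compound 1, `COc1cc(-c2nn(-c3ccc(NC(=O)Nc4ccc(Cl)c(Cl)c4)cc3)cc2-c2ccncc2)ccc1Cl`: in a functional assay on UACC-257 cells (Homo sapiens) for antiproliferative activity, read by sulforhodamine B assay, with a stated time of 48 h (a higher number here means a weaker inhibitor, a lower number a stronger inhibitor), compound 1 gives 3170 nM.
Compound 2, `COc1cc(-c2nn(-c3ccc(NC(=O)c4cc(Cl)cc(Cl)c4)cc3)cc2-c2ccncc2)ccc1Cl`: in this assay compound 2 gives only the limit > 100000 nM.
Compound 3, `COc1cc(-c2nn(-c3ccc(NC(=O)c4ccc(Cl)c(C(F)(F)F)c4)cc3)cc2-c2ccncc2)ccc1Cl`: in this assay compound 3 gives 5830 nM.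

Compound 3 and compound 1 sit within the scatter of each other, as a 1.8-fold higher number from compound 1 to compound 3 (0.26 log units; within the scatter) shows; the third value is a limit, so compound 3 stands beside compound 1 with no further number to set it against. The large steps seen so far, an at least 31-fold higher number from compound 1 to compound 2 (1.49 log units; beyond the scatter) and an at least 17-fold lower number from compound 2 to compound 3 (1.23 log units; beyond the scatter), all change the group on the carbonyl carbon, with the limit for compound 2 noted in the limit of > 100000 nM in this assay, at which 1 of the 3 values shown sits.

Compound 4, `O=C(Nc1ccc(-n2cc(-c3ccncc3)c(-c3ccc(Cl)c(O)c3)n2)cc1)c1ccc(Cl)c(C(F)(F)F)c1`, is not yet measured. It differs from compound 3 by hydrogen in place of methyl on an oxygen on an aromatic ring, that is, methoxy to hydroxy on the 4-chloro-3-methoxyphenyl group. For the measured compounds named here, none of the measured steps touches this oxygen, so no measured step bears directly on the change. Going by the values given here, with no precedent either way, compound 4 is expected to show a step of a 1.0-fold higher number from compound 3 to compound 4 (0.01 log units; within the scatter), that is, none beyond the scatter. Compound 4 is therefore estimated at 6000 nM, within 2500 nM to 15000 nM.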

Compound 4, half-maximal inhibitory concentration: 2550 nM
Compound 4: the middle estimate sits 2.4-fold (0.37 log units) above what was measured; the range from low to high includes it.
By their numbers in this assay, from the lowest: compounds 4, 1 and 3 (each within the scatter of the next, the first and the last beyond it). At a limit, above all of these: compound 2.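

In this assay, the change from methoxy to hydroxy on the 4-chloro-3-methoxyphenyl group gives a 2.3-fold lower number from compound 3 to compound 4 (0.36 log units; beyond the scatter), a modest step beyond the scatter. For the compounds shown here, this is the first sign that the oxygen on this aromatic ring affects the read-out, since every earlier step changed the group on the carbonyl carbon, and it shows that the methyl there can give way to hydrogen without loss of activity. Nothing given here accounts for the size or direction of this step.

On these data alone, only methoxy and hydroxy are seen at this position, so it stays open how an ethoxy group or an amine would compare. As far as these compounds go, it also stays open whether the same change would give a similar step on the (3,4-dichlorophenyl)amino carbonyl group of compound 1.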